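Nitro in Place of Bromo on the Benzylsulfanyl Arm

This account rests on a few compounds, and the source may have more. Where it says the series, first, only, none or still open, it means among the compounds named here.

Compound 1, `Cc1cc(N2CC[C@@H](C)[C@@H](N(C)c3ncnc4[nH]ccc34)C2)n2ncnc2n1`, gives 4350 nM in a functional assay on MGC-803 cells (Homo sapiens) for inhibition, read by MTT assay, with a stated time of 72 h; on this read-out lower numbers stand for stronger inhibition and higher numbers for weaker inhibition.
Compound 2, `Cc1cc(N2CC[C@@H](C)[C@@H](N(C)c3ncnc4[nH]ccc34)C2)n2nc(SCc3ccc(Br)cc3)nc2n1`, gives 4020 nM in this assay.

Among the compounds with values here, only two numbers have been measured so far. Compound 2 and compound 1 lie within the scatter of each other, as a 1.1-fold lower number from compound 1 to compound 2 (0.03 log units; within the scatter) shows, so compound 2 stands level with compound 1 rather than apart from it: attaching the whole (4-bromobenzyl)sulfanyl arm to the shared core left the read-out where it was.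

Compound 3, `Cc1cc(N2CC[C@@H](C)[C@@H](N(C)c3ncnc4[nH]ccc34)C2)n2nc(SCc3ccc([N+](=O)[O-])cc3)nc2n1`, has not yet been measured. It differs from compound 2 by nitro in place of bromo on an aromatic carbon.

Within the data shown here, the only measured step that bears on this is the one from compound 1 to compound 2, which built the arm and produced no movement beyond the scatter. Among the measured compounds shown here, no measured pair exchanges one group for another on that six-membered ring, so nothing seen so far points to a step in either direction. Compound 3 is therefore expected to give 4000 nM, in a range from 1800 nM to 9000 nM. The step this estimate implies is a 1.0-fold lower number from compound 2 to compound 3 (0.00 log units; within the scatter), expected to stay within the scatter.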

Compound 3, half-maximal inhibitory concentration: 27000 nM
Compound 3: middle estimate off by 6.8-fold (0.83 log units), on the low side; the measured number lies above the stated range.
By their numbers in this assay, from the lowest: compounds 2 and 1 (each within the scatter of the next); then compound 3.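

In this assay, putting nitro in place of bromo on the six-membered aromatic ring moved the number clearly upward (a 6.7-fold higher number from compound 2 to compound 3 (0.83 log units; beyond the scatter)), so this aromatic carbon, para to a large group, is not indifferent to what it carries. That could not be seen from the first step alone, where the (4-bromobenzyl)sulfanyl arm left the number level with the core of compound 1 (a 1.1-fold lower number from compound 1 to compound 2 (0.03 log units; within the scatter)), whereas the (4-nitrobenzyl)sulfanyl arm stands apart from that same core (a 6.2-fold higher number from compound 1 to compound 3 (0.79 log units; beyond the scatter)), so what the arm does in this read-out depends on the group on its ring rather than on the arm alone. No measurement offered here accounts for the step, which stands as an observation without an explanation.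

With only bromo and nitro shown at this carbon, a single pair cannot tell whether the rise is particular to nitro or would also appear with an amine, a methoxy group or a carboxylic acid there. Going by these compounds, it also remains open whether a plain phenyl ring, or a longer chain between the sulfur and the ring, would stay level with compound 2 or move as compound 3 does.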